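This account rests on a few compounds, and the source may have more. Where it says the series, first, only, none or still open, it means among the compounds named here.

Measured so far in an ADME assay on microsomes from liver (Rattus norvegicus) for metabolic stability, read by LC-MS, with a stated time of 10 min, tested at 0.5 uM; a lower number here means that less of the compound is left, a higher number that more of the compound is left:
compound 1, `CN1CCN(CCCN(C[C@H]2Cc3ccccc3CN2)[C@H]2CCCc3cccnc32)CC1`: 10%
compound 2, `c1ccc2c(c1)CN[C@@H](CN(CC[C@H]1CCCNC1)[C@H]1CCCc3cccnc31)C2`: 55%
compound 3, `c1cnc2c(c1)CCC[C@@H]2N(CCCN1CCNCC1)Cc1nc2ccccc2[nH]1`: 29%

Compound 1 stands lowest of the three numbers in this assay. Going by the values given here, its nearest neighbour is compound 3, whose number lies beyond the scatter above it; compound 2 lies furthest off, and the single step between measured compounds that differ in one place reads a number 45 percentage points higher from compound 1 to compound 2 (beyond the scatter). Compound 3 is not joined to compound 1 by a single change, so its number serves only as a second point of reference.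

Compound 4, `c1ccc2c(c1)CN[C@@H](CN(CCC1CCNCC1)[C@H]1CCCc3cccnc31)C2`, is not yet measured in this assay. Against compound 1 it differs in one place: piperidin-4-yl in place of (4-methylpiperazin-1-yl)methyl on a saturated chain carbon, two bonds along the chain from an amine nitrogen. Among the compounds with values here, the one measured step that bears on this change is a number 45 percentage points higher from compound 1 to compound 2 (beyond the scatter), where the same (4-methylpiperazin-1-yl)methyl leaves at the same place and piperidin-3-yl enters; here the entering group is piperidin-4-yl instead. That step was large and upward, so a step of the same kind is expected here, upward and beyond the scatter, with the caution that a single precedent is thin ground and the entering ring is not identical. Compound 4 is therefore expected to give 50% in this assay, within a range of 30% to 70%. This estimate means an expected step of a number 40 percentage points higher from compound 1 to compound 4 (beyond the scatter).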

Compound 4, percent of the compound remaining: 17%
For compound 4 the middle estimate is 33 percentage points above the measured one; the measured number lies below the stated range.
By their numbers in this assay, from the lowest: compounds 1 and 4 (each within the scatter of the next); then compound 3; then compound 2.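

Notes on the series, read in this assay: replacing (4-methylpiperazin-1-yl)methyl on a saturated chain carbon, two bonds along the chain from an amine nitrogen, does not by itself go with a higher number, since piperidin-4-yl as the entering group gives a number 7 percentage points higher from compound 1 to compound 4 (within the scatter), and the two compounds cannot be told apart here. The high reading of compound 2 therefore does not extend to every piperidinyl group at this place, and the choice between the two entering groups carries the large difference, with piperidin-4-yl in place of piperidin-3-yl giving a number 38 percentage points lower from compound 2 to compound 4 (beyond the scatter). No data at hand explain why these two closely related groups read so differently.

Still open, from the compounds shown here alone, is whether the higher number is confined to piperidin-3-yl in the form present in compound 2, or also holds for its mirror-image form or for related groups such as pyrrolidin-3-yl or 1-methylpiperidin-3-yl at the same place. Also open, going by these compounds, is how a longer or shorter chain carrying piperidin-3-yl would read in this assay.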